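A 3,4-dichlorophenyl swap at an assay limit

A few compounds are considered here, and "the series" means these few. Any claim that something is new, unique, unknown or untested is made for them only; others in the source may bear on it.

Compound 1 `C=C[C@@](C)(/C=C/c1ccc(OC)cc1)CCC=C(C)C`: > 36600 nM
Compound 2 `C=C[C@@](C)(/C=C/c1ccc(Nc2cc(F)cc(F)c2)cc1)CCC=C(C)C`: > 36600 nM
Compound 3 `C=C[C@@](C)(/C=C/c1ccc(Nc2ccc(Cl)c(Cl)c2)cc1)CCC=C(C)C`: > 36600 nM

These entries come from an ADME assay on HEK293 cells (Homo sapiens) for cytotoxicity, with a stated time of 72 h (a lower number here means that less compound is needed, a higher number that more compound is needed for the effect), and each is a limit rather than a number. Compound 3 stands only at its limit of > 36600 nM. It has company there: the limit of > 36600 nM in this assay, at which 3 of the 3 values shown sit.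

Compound 4 `C=C[C@@](C)(/C=C/c1ccc(-c2ccc(Cl)c(Cl)c2)cc1)CCC=C(C)C` differs from compound 3 in one place: 3,4-dichlorophenyl in place of (3,4-dichlorophenyl)amino on an aromatic carbon. In words, 3,4-dichlorophenyl takes the place of (3,4-dichlorophenyl)amino on an aromatic carbon.

The measured changes at this same place are a step that the two limits leave unreadable from compound 1 to compound 2, a step that the two limits leave unreadable from compound 1 to compound 3 and a step that the two limits leave unreadable from compound 2 to compound 3. None of them offers a size to carry over, so no step beyond the scatter is expected in this assay, in either direction. Compound 4 is expected to be reported as a limit too. The estimated change is a step that the limit leaves unreadable from compound 3 to compound 4. For compound 4 the estimate is 40000 nM, with an expected range from 20000 nM to 80000 nM.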

Compound 4, half-maximal effective concentration: > 36600 nM
Compound 4 gave a limit, no number; the forecaster's own chance of this, stated with the estimate: 85%; the middle value lies beyond the limit too.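

For the compounds shown here, compound 4 stands at a limit in this assay, like compound 1, compound 2 and compound 3, so no step from any of them to compound 4 can be read. All four share one reading: the limit of > 36600 nM in this assay, at which 4 of the 4 values shown sit. The compounds shown leave open how much of any of them is needed for the effect.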